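The source may hold more compounds than are shown below. What is called first, only, known or untested is meant among the compounds shown, and "the series" means these compounds.

Of the compounds shown here, three have been measured so far. In a functional assay on T47D cells (Homo sapiens) for cytotoxicity, read by sulforhodamine B assay, with a stated time of 48 h (a lower number here means a stronger inhibitor, a higher number a weaker inhibitor), compound 1 `CN(C)/C=C/C(=O)c1cc2ccccc2oc1=O` gives 147000 nM. Compound 2 `Cc1cc(NS(=O)(=O)c2ccc(N/C=C\C(=O)c3cc4ccccc4oc3=O)cc2)on1` gives 75600 nM, and compound 3 `O=C(/C=C\Nc1ccc(S(=O)(=O)Nc2ccccn2)cc1)c1cc2ccccc2oc1=O` gives 37600 nM, the lowest of the three numbers: its gap to compound 2 lies within the scatter of repeated measurements, while its gap to compound 1 lies beyond it. Going by the values given here, the only step between compounds that differ in one place is a 2.0-fold lower number from compound 2 to compound 3 (0.30 log units; within the scatter), a change of the group on the sulfonamide nitrogen that left the number within the scatter.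

Compound 4 `O=C(/C=C\Nc1ccc(S(=O)(=O)Nc2cnc3ccccc3n2)cc1)c1cc2ccccc2oc1=O` carries the change (quinoxalin-2-yl in place of pyridin-2-yl on a sulfonamide nitrogen). This is the same kind of change as the one that bears on it, and that change produced no shift beyond the scatter, so no step beyond the scatter is expected here either. The step of a 1.3-fold lower number from compound 3 to compound 4 (0.10 log units; within the scatter) is expected to fall within the scatter. Compound 4 is therefore estimated to give 30000 nM, with a range from 10000 nM to 90000 nM.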

Compound 4, half-maximal inhibitory concentration: 86900 nM
Beside the measured number, compound 4's estimate is 2.9-fold (0.46 log units) below it; the range from low to high includes it.
By their numbers in this assay, from the lowest: compounds 3, 2, 4 and 1 (each within the scatter of the next, the first and the last beyond it).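

In this assay, a 2.3-fold higher number from compound 3 to compound 4 (0.36 log units; beyond the scatter) is the only step shown at the sulfonamide nitrogen that passes the scatter, so the group at this place can shift the number, though only modestly. The two-ring quinoxalin-2-yl does not stand apart from every single-ring group, however: a 1.1-fold higher number from compound 2 to compound 4 (0.06 log units; within the scatter) leaves it level with the 3-methyl-1,2-oxazol-5-yl group, and only the comparison with pyridin-2-yl exceeds the scatter. Nothing measured here explains why this change moves the number.

All the groups shown on the sulfonamide nitrogen are aromatic rings, so the effect of a methyl group or a longer alkyl chain at this place remains open. Also open, going by these compounds, is whether any group here can move the number further than these modest steps.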